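This account rests on a few compounds, and the source may have more. Where it says the series, first, only, none or still open, it means among the compounds named here.

In a functional assay on HepG2 cells (Homo sapiens) for antiproliferative activity, read by MTT assay, with a stated time of 48 h (on this read-out higher numbers stand for weaker inhibition and lower numbers for stronger inhibition), compound 1 (`COc1ccc(-c2ccc3c(c2)C(=O)C(=O)N3)cc1`) gives 960 nM with the amide hydrogen in place. Compound 2 (`COc1ccc(-c2ccc3c(c2)C(=O)C(=O)N3Cc2ccc(Cl)cc2)cc1`) carries a 4-chlorobenzyl on that nitrogen and gives 250 nM as its reading, which makes a 3.8-fold lower number from compound 1 to compound 2 (0.58 log units; beyond the scatter) for this one added group. Compound 3 (`COc1ccc(-c2ccc3c(c2)C(=O)C(=O)N3Cc2ccccc2Cl)cc1`) carries a 2-chlorobenzyl there instead and gives 600 nM as its reading. It therefore stands close to compound 1, with a 1.6-fold lower number from compound 1 to compound 3 (0.20 log units; within the scatter) on adding the group, while a 2.4-fold higher number from compound 2 to compound 3 (0.38 log units; beyond the scatter) separates it from the 4-chloro compound.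

Compound 4 (`COc1ccc(-c2ccc3c(c2)C(=O)C(=O)N3Cc2ccccc2OC)cc1`) has not yet been measured. The change is methoxy in place of chloro on an aromatic carbon with methoxy in place of chloro on an aromatic carbon, ortho to a large group, so 2-chlorobenzyl becomes 2-methoxybenzyl. Within the data shown here, no measured step makes this swap, so the evidence is indirect. The nearest guide is the pair of chloro compounds, where the largest step among the benzyl groups is the modest 2.4-fold higher number from compound 2 to compound 3 (0.38 log units; beyond the scatter) on moving the chloro group. A step of that size gives no firm reason to expect a large shift, and the direction stays open.

For compound 4 the expected step is small, at a 1.1-fold lower number from compound 3 to compound 4 (0.04 log units; within the scatter) in the estimate, with no change beyond the scatter expected. Compound 4 is expected to read about 550 nM (estimated range 230 nM to 1300 nM).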

Compound 4, half-maximal inhibitory concentration: 130 nM
Compound 4: middle estimate off by 4.2-fold (0.63 log units), on the high side; the measured number lies below the stated range.
By their numbers in this assay, from the lowest: compounds 4 and 2 (each within the scatter of the next); then compounds 3 and 1 (each within the scatter of the next).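

In this assay, the result shows that the carbon ortho to a large group is not a poor place for a substituent in itself: with chloro on it the benzyl group added little, but methoxy in place of chloro gives a 4.6-fold lower number from compound 3 to compound 4 (0.66 log units; beyond the scatter) and so the identity of the group there matters, not only its place. Measured against the bare amide hydrogen, the 2-methoxybenzyl group gives a 7.4-fold lower number from compound 1 to compound 4 (0.87 log units; beyond the scatter) and this step lies beyond the scatter, whereas the step for the 2-chlorobenzyl group stayed within it. The 2-methoxybenzyl group also reaches the level of the 4-chlorobenzyl group, with a 1.9-fold lower number from compound 2 to compound 4 (0.28 log units; within the scatter) being too small a step to separate the two, so moving or changing the benzyl substituent can each recover the same range of numbers.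

The compounds shown leave open whether methoxy would read the same at another carbon of the benzyl ring, and how a hydroxyl group or an amine would read on this same aromatic carbon. Nothing measured here gives a reason for the difference between methoxy and chloro at this place.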